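Swapping a Furan for an Imidazole on an Aryl Amine

This account rests on a few compounds, and the source may have more. Where it says the series, first, only, none or still open, it means among the compounds named here.

Four compounds share an aromatic nitrile carrying an amine. In a functional assay on PC-3 cells (Homo sapiens) for antiproliferative activity, read by CCK-8 assay, with a stated time of 6 days (on this read-out lower numbers stand for stronger inhibition and higher numbers for weaker inhibition), compound 1 `N#Cc1ccc(N2CCc3cc(-c4cccnc4)ccc32)cc1C(F)(F)F` is recorded as "not determined" (no result reported). Compound 2 `CCN(c1ccc(C#N)c(Cl)c1)c1cc(-c2cnc3ccccc3c2)ccc1C` gives 3570 nM in this assay. Compound 3 `CCN(c1ccc(C#N)c(Cl)c1)c1cc(-c2ccco2)ccc1C` reaches only a limit of this assay, reported as > 30000 nM. Compound 3 thus stands at the limit end of the numbers shown, as the limit of > 30000 nM in this assay, at which 1 of the 3 values shown sits, marks. Compound 4 `CCN(c1ccc(C#N)c(Cl)c1)c1cc(-n2ccnc2)ccc1C` differs from compound 3 by 1H-imidazol-1-yl in place of furan-2-yl on an aromatic carbon. Among the compounds with values here, with no measured step of this kind to lean on, only a modest shift toward stronger inhibition is expected, near the edge of the scatter, as the step of an at least 1.5-fold lower number from compound 3 to compound 4 (0.17 log units; that floor lies within the scatter) expresses. Compound 4 is therefore estimated at 20000 nM, expected between 6000 nM and 60000 nM, with a fair chance of again being reported as a limit.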

Compound 4, half-maximal inhibitory concentration: > 30000 nM
Compound 4 ended at the assay's limit; the forecaster's own chance of this, stated with the estimate: 50%; middle value at least 1.5-fold (0.17 log units) away from the limit.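

Within the data shown here, compound 3 and compound 4 both end at a limit rather than a number, so no step between them can be read: the limit of > 30000 nM in this assay, at which 2 of the 4 values shown sit. On these data alone, whether furan-2-yl or 1H-imidazol-1-yl gives stronger inhibition in this assay remains open.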